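This account rests on a few compounds, and the source may have more. Where it says the series, first, only, none or still open, it means among the compounds named here.

Compound 3 `COC(=O)c1ccc(C2SCC(=O)N2c2ccc(N3CCNCC3)cn2)c(OC)c1` carries a hydrogen on an amine nitrogen in a ring where the other two measured compounds carry an arylsulfonyl group. In a functional assay on NALM-6 cells (Homo sapiens) for antiproliferative activity, read by MTT assay and trypan blue exclusion, with a stated time of 72 h (on this read-out higher numbers stand for weaker inhibition and lower numbers for stronger inhibition), compound 3 gives 9710 nM, the lowest of the two numbers shown. Compound 2 `COC(=O)c1ccc(C2SCC(=O)N2c2ccc(N3CCN(S(=O)(=O)c4cc(Cl)ccc4Cl)CC3)cn2)c(OC)c1` gives 27400 nM in this assay. Compound 1 `COC(=O)c1ccc(C2SCC(=O)N2c2ccc(N3CCN(S(=O)(=O)c4ccc([N+](=O)[O-])cc4)CC3)cn2)c(OC)c1` reaches only a limit of this assay, > 100000 nM, and the limit of > 100000 nM in this assay, at which 1 of the 3 values shown sits, therefore yields no number for it. Among the measured steps, an at least 3.6-fold lower number from compound 1 to compound 2 (0.56 log units; beyond the scatter), while the two that matter here are the removals of the sulfonyl group: a 2.8-fold lower number from compound 2 to compound 3 (0.45 log units; beyond the scatter) and an at least 10-fold lower number from compound 1 to compound 3 (1.01 log units; beyond the scatter), both moving toward lower numbers as the hydrogen entered.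

Compound 4 `COC(=O)c1ccc(C2SCC(=O)N2c2ccc(N3CCN(S(=O)(=O)c4c(C)cc(C)cc4C)CC3)cn2)c(OC)c1` is the member not yet measured. Its difference from compound 3 is this: (2,4,6-trimethylphenyl)sulfonyl in place of hydrogen on an amine nitrogen in a ring. Since both known steps in which a hydrogen replaced an arylsulfonyl group lowered the number, putting an arylsulfonyl group back in compound 4 is expected to raise it, by a step estimated as a 2.9-fold higher number from compound 3 to compound 4 (0.46 log units; beyond the scatter). The expected value for compound 4 in this assay is accordingly 28000 nM, with a likely range from 10000 nM to 90000 nM.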

Compound 4, half-maximal inhibitory concentration: > 100000 nM
Compound 4: a limit, no number (the forecaster's own chance of this, stated with the estimate: 20%); at least 3.5-fold (0.55 log units) between middle value and limit.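

In this assay, (2,4,6-trimethylphenyl)sulfonyl on the amine nitrogen in the ring gives an at least 10-fold higher number from compound 3 to compound 4 (1.01 log units; beyond the scatter), so all three arylsulfonyl compounds now carry higher numbers than the compound with hydrogen at this nitrogen, and none of the compounds shown goes against this. Exchanging only the aryl group on the sulfonyl sulfur gives an at least 3.6-fold higher number from compound 2 to compound 4 (0.56 log units; beyond the scatter), which shows that 2,5-dichlorophenyl is not matched here by a second substituted phenyl group, just as it was not by 4-nitrophenyl. Compound 2 thus remains the only arylsulfonyl compound with a number, and the step between compound 1 and compound 4 cannot be read because both values are limits: the limit of > 100000 nM in this assay, at which 2 of the 4 values shown sit.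

The compounds shown leave open whether the higher numbers follow from any group on this nitrogen or only from an arylsulfonyl group, since a methyl, an acetyl or a methylsulfonyl group does not appear among them. They also leave open how far the number of compound 3 depends on the rest of the molecule, for example on the methyl ester as against a carboxylic acid.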